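The source may hold more compounds than are shown below. What is called first, only, known or untested is meant among the compounds shown, and "the series" means these compounds.

In an ADME assay on the whole organism (strain CD-1) for metabolic stability, with Mus musculus as the target, at a dose of 3 mg/kg by the intravenous route (on this read-out higher numbers stand for a longer-lived compound and lower numbers for a shorter-lived compound), compound 1 `CN(Cc1ccccc1OCCCCCC(=O)O)C(=O)c1ccc(-c2ccco2)cc1` reads 1.7 h and compound 2 `C[C@@H](CCCOc1ccccc1CN(C)C(=O)c1ccc(-c2ccco2)cc1)CC(=O)O` reads 2 h while compound 3 `C/C(=C\C(=O)O)CCCOc1ccccc1CN(C)C(=O)c1ccc(-c2ccco2)cc1` reads 1.6 h on the same scale. Compound 3 therefore stands within the scatter of both others, and no order among the three can be claimed. Compound 4 `CC(CCOc1ccccc1CN(C)C(=O)c1ccc(-c2ccco2)cc1)CCC(=O)O` has not yet been measured. It departs from compound 3 by 3-carboxy-1-methylpropyl in place of 3-carboxy-2-methylprop-2-en-1-yl on a saturated chain carbon, two bonds along the chain from an oxygen on an aromatic ring and so carries a saturated chain with its methyl and its carboxy group.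

Going by the values given here, three measured steps bear on this change. Adding a methyl to the saturated chain gave a 1.2-fold higher number from compound 1 to compound 2 (0.07 log units; within the scatter) and bringing in 2-carboxy-1-methylethenyl in place of 2-carboxyethyl gave a 1.1-fold lower number from compound 1 to compound 3 (0.03 log units; within the scatter) as the result. The closest comparison is a 1.3-fold lower number from compound 2 to compound 3 (0.10 log units; within the scatter) as the third step. It sets 2-carboxy-1-methylethenyl against the saturated 1-(carboxymethyl)ethyl. Among the compounds with values here, all three lie within the scatter, although none is the same change as the one leading to compound 4. No step beyond the scatter is therefore expected in this assay for this change. The expected move is a 1.1-fold higher number from compound 3 to compound 4 (0.05 log units; within the scatter) and no more. For compound 4 the estimate is 1.8 h with an expected range from 1.1 h to 3 h when it is measured.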

Compound 4, half-life: 1.7 h
The estimate for compound 4 lay 1.1-fold (0.02 log units) above the measured number, within the range that was stated.
By their numbers in this assay, from the lowest: compounds 3, 1, 4 and 2 (each within the scatter of the next).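

In this assay, the unsaturated chain of compound 3 gave way to a saturated one with its methyl elsewhere, 3-carboxy-1-methylpropyl in place of 3-carboxy-2-methylprop-2-en-1-yl on a saturated chain carbon, two bonds along the chain from an oxygen on an aromatic ring, and the result was a 1.1-fold higher number from compound 3 to compound 4 (0.03 log units; within the scatter) for this change. The earlier compounds shown here offered only one saturated branched chain, and the second now stands against it, with 3-carboxy-1-methylpropyl in place of 2-(carboxymethyl)propyl giving a 1.2-fold lower number from compound 2 to compound 4 (0.07 log units; within the scatter) in this comparison. Set against the unbranched chain, the new branched chain gave no change at the digits printed from compound 1 to compound 4 (within the scatter) as its step, so at this position neither saturated branched chain nor the unsaturated one separates from the unbranched chain, and none of the four compounds goes against that.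

From the compounds shown here alone, whether a tetrazole or a primary amide in place of the carboxylic acid, or a much shorter chain, would keep the half-life within the same narrow band remains open. Nothing available here explains why these chains read alike.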